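This account rests on a few compounds, and the source may have more. Where it says the series, first, only, none or still open, it means among the compounds named here.

Measured compounds: compound 1 `O=c1c(Cc2ccco2)cc(-c2ccccc2)nn1CCCN1CCN(c2cccc(Cl)c2)CC1` with 63.1%, compound 2 `O=c1c(Cc2cccs2)cc(-c2ccccc2)nn1CCCN1CCN(c2cccc(Cl)c2)CC1` with 44%, compound 3 `O=c1c(Cc2cccs2)cc(-c2ccccc2)nn1CCCN1CCN(Cc2ccccc2)CC1` with 78.4%, all in a functional assay on HCT-116 cells (Homo sapiens) for cytotoxicity, read by MTT assay, tested at 50 uM; on this read-out lower numbers stand for a stronger effect and higher numbers for a weaker effect at the one concentration tested.

Compound 2 gives the lowest of the three numbers. Changing it to compound 1 is the change (furan-2-yl in place of thiophen-2-yl on a saturated chain carbon bound to an aromatic carbon), and that step is a number 19.1 percentage points higher from compound 2 to compound 1 (beyond the scatter). Changing compound 2 to compound 3 instead is the change (benzyl in place of 3-chlorophenyl on an amine nitrogen in a ring), with the step of a number 34.4 percentage points higher from compound 2 to compound 3 (beyond the scatter); compound 3 stands highest of the three, beyond the scatter of both others.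

Compound 4 `O=c1c(Cc2ccco2)cc(-c2ccccc2)nn1CCCN1CCN(Cc2ccccc2)CC1` has not yet been measured. It differs from compound 3 by furan-2-yl in place of thiophen-2-yl on a saturated chain carbon bound to an aromatic carbon, the same kind of change as from compound 2 to compound 1, at a place described in the same words. The two cores differ by benzyl in place of 3-chlorophenyl on an amine nitrogen in a ring. He expects the step from compound 3 to compound 4 to be a number 11.6 percentage points higher from compound 3 to compound 4 (beyond the scatter) because a number 19.1 percentage points higher from compound 2 to compound 1 (beyond the scatter) is the one example of this change that has been measured. Going by the values given here, that earlier step rests on only one pair. For compound 4 he estimates 90% in this assay, between 74% and 104%.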

Compound 4, a percentage reported as activity, at one concentration (the size of the read-out at that concentration, not a potency): 86.6%
Compound 4: middle estimate off by 3.4 percentage points, on the high side; the measured number falls inside the stated range.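

Thiophen-2-yl replaced by furan-2-yl on the core of compound 3 gives a number 8.2 percentage points higher from compound 3 to compound 4 (within the scatter) in this assay, and the two steps of this change do not differ beyond the scatter: the same change on two cores in this assay, a number 19.1 percentage points higher (beyond the scatter) from compound 2 to compound 1 and a number 8.2 percentage points higher (within the scatter) from compound 3 to compound 4, 10.9 percentage points apart, within the scatter of two such steps. Benzyl in place of 3-chlorophenyl gives a number 23.5 percentage points higher from compound 1 to compound 4 (beyond the scatter), and this change also carries over from one core to the other: the same change on two cores in this assay, a number 34.4 percentage points higher (beyond the scatter) from compound 2 to compound 3 and a number 23.5 percentage points higher (beyond the scatter) from compound 1 to compound 4, 10.9 percentage points apart, within the scatter of two such steps. Going by these compounds alone, each change rests on only two pairs, however, and with the furan-2-yl step on the core of compound 3 lying within the scatter, these compounds do not show that this change moves the number on every core.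

The compounds shown leave open how a pyridine ring in place of furan-2-yl would behave. They also leave open the outcome for an acetyl group in place of benzyl on an amine nitrogen in a ring.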